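Pyridinyl for methylsulfonylphenyl: cytotoxicity outlook for compound 4

A few compounds are considered here, and "the series" means these few. Any claim that something is new, unique, unknown or untested is made for them only; others in the source may bear on it.

compound 1 `CC(=O)N1CCC(C(=O)N(CCCN2CCN(Cc3ccc(S(C)(=O)=O)cc3)CC2)c2ccc(C)c(Cl)c2)CC1`: > 49200 nM
compound 2 `CC(=O)N1CCC(C(=O)N(CCCN2CCC(CNc3cc(C)ccn3)CC2)c2ccc(C)c(Cl)c2)CC1`: 17900 nM
compound 3 `CC(=O)N1CCC(C(=O)N(CCCN2CCC(Oc3ccccc3)CC2)c2ccc(C)c(Cl)c2)CC1`: > 56600 nM

In an ADME assay (Homo sapiens) for cytotoxicity (a higher number here means that more compound is tolerated, a lower number that less compound is tolerated), compound 1 gives > 49200 nM, which is a limit of the assay and not a number. Compound 3 also reaches only a limit in this assay, > 56600 nM. Within the data shown here, compound 2 is the one compound of the three with a number, giving 17900 nM in this assay. So compound 1 stands at the tolerant end of what has been measured, together with compound 3, though only as a limit (the limit of > 49200 nM in this assay, at which 1 of the 3 values shown sits). Among the measured compounds shown here, the only measured step is an at least 3.1-fold higher number from compound 2 to compound 3 (0.49 log units; beyond the scatter), in which the compound carrying a pyridine ring gave a number and the compound without it gave a limit.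

Compound 4 `CC(=O)N1CCC(C(=O)N(CCCN2CCN(Cc3ccncc3)CC2)c2ccc(C)c(Cl)c2)CC1` differs from compound 1 by pyridin-4-yl in place of 4-(methylsulfonyl)phenyl on a saturated chain carbon bound to an amine nitrogen in a ring. For the measured compounds named here, no measured pair carries this same change; the step from compound 2 to compound 3 is the only guide, and it points the other way, with a pyridine ring leaving and the tolerated concentration rising. A modest drop in tolerated concentration is therefore expected for compound 4, namely an at least 1.6-fold lower number from compound 1 to compound 4 (0.21 log units; that floor lies within the scatter), with a fair chance that the assay again reports only a limit. Compound 4 is estimated at 30000 nM in this assay, within 12000 nM to 60000 nM.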

Compound 4, half-maximal cytotoxic concentration: > 56700 nM
Compound 4: no number, only a limit; the forecaster's own chance of this, stated with the estimate: 40%; middle value at least 1.8-fold (0.27 log units) away from the limit.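

In this assay compound 4 gives > 56700 nM, which is a limit of the assay and not a number. Among these compounds, compound 1 also stands only at a limit, so no step from compound 1 to compound 4 can be read. On these data alone, whether pyridin-4-yl in place of 4-(methylsulfonyl)phenyl changes the tolerated concentration at all remains open.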